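This account rests on a few compounds, and the source may have more. Where it says the series, first, only, none or still open, it means among the compounds named here.

Compound 1 `O=S(=O)(Nc1ccc(-c2nc3ccccc3o2)cc1)c1ccccc1O` gives > 100000 nM in an ADME assay on HEK293 cells (Homo sapiens) for cytotoxicity, read by resazurin assay, with a stated time of 48 h (on this read-out lower numbers stand for higher toxicity in this test and higher numbers for lower toxicity in this test), which is a limit of the assay and not a number.
Compound 2 `CCc1ccc(S(=O)(=O)Nc2ccc3oc(-c4ccccc4)nc3c2)cc1` gives 81000 nM in this assay.
Compound 3 `CCc1ccc(S(=O)(=O)Nc2ccc(-c3nc4ccccc4o3)cc2)cc1` gives 82000 nM in this assay.

Compounds 2 and 3 are built from the same atoms joined differently; how their two cores differ is not broken down here. Their numbers in this assay lie within the scatter of each other, so nothing separates them. Compound 1 carries the change 2-hydroxyphenyl in place of 4-ethylphenyl on a sulfonyl sulfur relative to compound 3, and the step of an at least 1.2-fold higher number from compound 3 to compound 1 (0.08 log units; that floor lies within the scatter) is bounded by the limit of > 100000 nM in this assay, at which 1 of the 3 values shown sits, at which the value of compound 1 sits.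

Compound 4 `O=S(=O)(Nc1ccc2oc(-c3ccccc3)nc2c1)c1ccccc1O` has not yet been measured. It differs from compound 2 by 2-hydroxyphenyl in place of 4-ethylphenyl on a sulfonyl sulfur, the same change as that from compound 3 to compound 1. The step in this assay is expected to be a 1.4-fold higher number from compound 2 to compound 4 (0.13 log units; within the scatter), resting on the step of an at least 1.2-fold higher number from compound 3 to compound 1 (0.08 log units; that floor lies within the scatter) and on the closeness of the numbers of compound 2 and compound 3. Compound 4 is therefore estimated at 110000 nM, between 60000 nM and 250000 nM, with a fair chance that only a limit is reported.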

Compound 4, half-maximal cytotoxic concentration: 33000 nM
Beside the measured number, compound 4's estimate is 3.3-fold (0.52 log units) above it; measured number outside the range, below it.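

The change 2-hydroxyphenyl in place of 4-ethylphenyl on a sulfonyl sulfur brings a 2.5-fold lower number from compound 2 to compound 4 (0.39 log units; beyond the scatter) in this assay, and it does not carry over as one fixed step from one core to the other: the same change on two cores in this assay, an at least 1.2-fold higher number (0.08 log units; that floor lies within the scatter) from compound 3 to compound 1 and a 2.5-fold lower number (0.39 log units; beyond the scatter) from compound 2 to compound 4, at least 2.9-fold (0.47 log units) apart, beyond the scatter of two such steps. From the compounds shown here alone, compound 1 gives > 100000 nM, which is a limit of the assay and not a number, so the step on its core has only a floor and its full size remains unknown: the limit of > 100000 nM in this assay, at which 1 of the 4 values shown sits. For the compounds shown here, with only two pairs, this shows that the step depends on the core here, but it does not show how the change would behave on any further core, and it gives no explanation for the difference.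

The compounds shown leave open whether the step comes from losing the ethyl group or from gaining the hydroxyl group, which an unsubstituted phenyl on a sulfonyl sulfur on both cores would help to separate. They also leave open how an amine or a carboxylic acid in place of that hydroxyl group would read on either core.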